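Aryl swap at the acyl chain of compound 2

The source may hold more compounds than are shown below. What is called first, only, known or untested is meant among the compounds shown, and "the series" means these compounds.

Compound 1 `O=C1C=CCC(/C=C/c2ccccc2)N1`: in a functional assay on PANC-1 cells (Homo sapiens) for cytotoxicity, read by MTT assay, with a stated time of 24 h (on this read-out higher numbers stand for weaker inhibition and lower numbers for stronger inhibition), compound 1 reaches only > 100000 nM, which is a limit of the assay and not a number.
Compound 2 `C/C=C/C(=O)N1C(=O)C=CCC1/C=C/c1ccccc1`: in this assay compound 2 gives 4200 nM.
Compound 3 `C=CC(=O)N1C(=O)C=CCC1/C=C/c1ccccc1`: in this assay compound 3 gives 8100 nM.

Compound 2 holds the lowest of the two numbers, with compound 3 nearest to it, a 1.9-fold higher number from compound 2 to compound 3 (0.29 log units; within the scatter). Compound 1 sits at the limit of > 100000 nM in this assay, at which 1 of the 3 values shown sits. Placing an acyl group on the amide-type nitrogen in the ring gave the large steps of an at least 23-fold lower number from compound 1 to compound 2 (1.37 log units; beyond the scatter) and an at least 12-fold lower number from compound 1 to compound 3 (1.09 log units; beyond the scatter), whereas the exchange of vinyl for prop-1-en-1-yl on the carbonyl carbon gave a 1.9-fold higher number from compound 2 to compound 3 (0.29 log units; within the scatter).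

Compound 4 `COc1cc(/C=C/C(=O)N2C(=O)C=CCC2/C=C/c2ccccc2)ccc1O` differs from compound 2 by 4-hydroxy-3-methoxyphenyl in place of methyl on a double-bonded chain carbon bound to a double-bonded chain carbon. For the measured compounds named here, the only measured step touching that chain is the one from compound 2 to compound 3, and it stayed within the scatter; none of the measured steps adds a ring there. Compound 4 is therefore expected to give 3500 nM in this assay, between 1000 nM and 12000 nM. The expected step is a 1.2-fold lower number from compound 2 to compound 4 (0.08 log units; within the scatter), which is not beyond the scatter.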

Compound 4, half-maximal inhibitory concentration: 15600 nM
Compound 4: the middle estimate sits 4.5-fold (0.65 log units) below what was measured, outside the stated range (above it).
By their numbers in this assay, from the lowest: compounds 2, 3 and 4 (each within the scatter of the next, the first and the last beyond it). At a limit, above all of these: compound 1.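

In this assay, 4-hydroxy-3-methoxyphenyl in place of methyl gave a 3.7-fold higher number from compound 2 to compound 4 (0.57 log units; beyond the scatter), so this chain carbon, where the exchange of vinyl for prop-1-en-1-yl had given only a 1.9-fold higher number from compound 2 to compound 3 (0.29 log units; within the scatter), does respond to what is placed on it. The change is modest, and with the added ring on this carbon compound 4 still gives a measured number, 15600 nM, and not a limit. Nothing among the data shown accounts for this step.

The effect of the ring itself cannot yet be told apart from that of its hydroxy and methoxy groups, a question that a plain phenyl on this carbon would address. Going by these compounds, how an amine or a carboxylic acid on that ring would read also remains open.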